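Adding a Methyl on the Amide-Linked Chain Carbon

The source may hold more compounds than are shown below. What is called first, only, known or untested is meant among the compounds shown, and "the series" means these compounds.

Measured so far:
compound 1, `CC(C)=CCC/C(C)=C/CC/C(C)=C/CSc1ccccc1C(=O)NCC(=O)OCC#CCOc1no[n+]([O-])c1S(=O)(=O)c1ccccc1`, gives 11700 nM
compound 2, `CC(C)=CCC/C(C)=C/CC/C(C)=C/CSc1ccccc1C(=O)N1CCC[C@H]1C(=O)OCC#CCOc1no[n+]([O-])c1S(=O)(=O)c1ccccc1`, gives 3560 nM

In a functional assay on U-251 cells (Homo sapiens) for cytotoxicity, read by MTT assay, with a stated time of 48 h (on this read-out lower numbers stand for stronger inhibition and higher numbers for weaker inhibition), compound 1 stands with the highest of the two numbers, and compound 2 sits at a lower number by a gap that lies beyond the usual scatter. For the measured compounds named here, the two differ in more than one place, so no single step between them is counted.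

Compound 3, `CC(C)=CCC/C(C)=C/CC/C(C)=C/CSc1ccccc1C(=O)N[C@@H](C)C(=O)OCC#CCOc1no[n+]([O-])c1S(=O)(=O)c1ccccc1`, is yet to be measured. It differs from compound 1 by methyl in place of hydrogen on a saturated chain carbon bound to an amide-type nitrogen and a carbonyl carbon. Going by the values given here, no measured pair shows this change on its own, so its size is not known from the data. Since compound 1 holds the higher of the two numbers, a small downward step is expected, a 1.6-fold lower number from compound 1 to compound 3 (0.19 log units; within the scatter), with no strong reason for a large one. Compound 3 is expected to give 7500 nM, most likely between 3000 nM and 18000 nM.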

Compound 3, half-maximal inhibitory concentration: 7310 nM
Beside the measured number, compound 3's estimate is 1.0-fold (0.01 log units) above it, and the stated range covers the measured number.
By their numbers in this assay, from the lowest: compound 2; then compounds 3 and 1 (each within the scatter of the next).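

In this assay, for the compounds shown here, the first step that isolates this position reads a 1.6-fold lower number from compound 1 to compound 3 (0.20 log units; within the scatter), for methyl in place of hydrogen on a saturated chain carbon bound to an amide-type nitrogen and a carbonyl carbon. The added carbon therefore leaves compound 3 and compound 1 indistinguishable on this read-out, so this one position accepts a methyl with no effect that can be told apart from ordinary repeat variation. No accompanying measurement bears on this result.

What the compounds shown leave open is how far this tolerance extends on the same carbon, for instance to a longer chain such as ethyl, to a benzyl group, or to a hydroxymethyl group. The methyl of opposite handedness also remains an open question.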